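The compounds below may be only part of what the source reports. "The series", "measured", "known", "first", "only" and "open" are said of these compounds alone.

Among the compounds with values here, in a functional assay on NCI-H460 cells (Homo sapiens) for inhibition, read by MTT assay, with a stated time of 24 h, tested at 100 ug/mL (a lower number here means less inhibition of growth, a higher number more inhibition of growth at the concentration tested), compound 1 (`CC(=O)SCCC(CCCCC(=O)O)SC(C)=O`) gives 11%, the lowest of the three numbers so far. Compound 2 (`O=C(CCCCC(S)CCS)NO`) gives 43.7% and compound 3 (`O=C(CCCCC1CCSS1)Nc1ccccn1`) gives 39.3%. These two lie within the scatter of each other, and both lie beyond the scatter from compound 1.

Compound 4 (`CC(=O)SCCC(CCCCC(=O)Nc1ccccc1Cl)SC(C)=O`) has not yet been measured. It keeps the core of compound 1 and changes only the group on the carbonyl carbon: (2-chlorophenyl)amino in place of hydroxy on a carbonyl carbon. Here (2-chlorophenyl)amino stands in place of hydroxy on a carbonyl carbon.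

Within the data shown here, no measured pair isolates this change, since compound 2 and compound 3 also differ from compound 1 in their sulfur groups. The evidence is therefore indirect. Both carry a nitrogen on the carbonyl carbon where compound 1 has hydroxy, and both sit well clear of it. The closest guide is compound 3 at 39.3%, which also has an aromatic ring on that nitrogen.

An upward move in this assay is therefore expected, beyond the scatter but with wide uncertainty. The estimated step is a number 24 percentage points higher from compound 1 to compound 4 (beyond the scatter), towards more inhibition of growth. For compound 4 the estimate is 35%, with an expected range of 20% to 55%.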

Compound 4, percent growth inhibition at one concentration: 15.2%
Beside the measured number, compound 4's estimate is 19.8 percentage points above it, outside the stated range (below it).
By their numbers in this assay, from the lowest: compounds 1 and 4 (each within the scatter of the next); then compounds 3 and 2 (each within the scatter of the next).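

In this assay the step is a number 4.2 percentage points higher from compound 1 to compound 4 (within the scatter), so on this core, (2-chlorophenyl)amino in place of hydroxy on a carbonyl carbon leaves the read-out unchanged within the scatter, even though a six-membered aromatic ring and eight heavy atoms enter where one left. Within the data shown here, this is the first comparison that isolates a single place, and it shows that this amide change alone does not carry the growth inhibition at the concentration tested. No supporting measurement is available to explain this flat step.

The compounds shown leave open whether another group on the same carbonyl carbon, such as benzylamino, an unsubstituted phenylamino or a methyl ester, would move the number on this core. They also leave open whether the (2-chlorophenyl)amino group would give a different result with the two acetylthio groups replaced by free thiols, a change that would need its own single-place comparison.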